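Methoxy in Place of Propanoylamino: Vero Cell Cytotoxicity

The source may report more compounds than this note shows. Statements on the series, on what has been measured and on what is new or still open speak of the compounds shown alone.

Compound 1 `Oc1ccc(-c2nc3cc(C(F)(F)F)ccc3[nH]2)cc1`, compound 2 `O=[N+]([O-])c1ccc(-c2nc3cc(C(F)(F)F)ccc3[nH]2)cc1` and compound 3 `CCC(=O)Nc1ccc(-c2nc3cc(C(F)(F)F)ccc3[nH]2)cc1` were measured in an ADME assay on Vero cells (Chlorocebus sabaeus) for cytotoxicity; on this read-out lower numbers stand for higher toxicity in this test and higher numbers for lower toxicity in this test. Compound 1 gives > 100000 nM, a limit of the test. Compound 2 gives 45000 nM. Compound 3 gives > 100000 nM, again a limit.

Compound 3 therefore sits at the limit of > 100000 nM in this assay, at which 2 of the 3 values shown sit, together with compound 1. Compound 4 `COc1ccc(-c2nc3cc(C(F)(F)F)ccc3[nH]2)cc1` differs from it by methoxy in place of propanoylamino on an aromatic carbon. The measured steps give only partial guidance: a step that the two limits leave unreadable from compound 1 to compound 3, while an at least 2.2-fold higher number from compound 2 to compound 3 (0.34 log units; beyond the scatter). Among the measured compounds shown here, no measured step involves a methoxy group. Since both the hydroxy compound and the propanoylamino compound sit at the limit, no shift beyond the scatter is expected. Compound 4 is estimated at 120000 nM, within 50000 nM to 300000 nM. The expected step is a step that the limit leaves unreadable from compound 3 to compound 4, essentially flat, most likely reported again as a limit.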

Compound 4, half-maximal cytotoxic concentration: 15000 nM
Estimate against measurement, compound 4: 8.0-fold (0.90 log units) above, outside the stated range (below it).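

At this position, methoxy is not a neutral choice in this assay: it gives an at least 6.6-fold lower number from compound 3 to compound 4 (0.82 log units; beyond the scatter), and adding one methyl to the oxygen of the hydroxy group gives an at least 6.6-fold lower number from compound 1 to compound 4 (0.82 log units; beyond the scatter). Methoxy also goes further than nitro, which had been the only group to lower the number, with a 3.0-fold lower number from compound 2 to compound 4 (0.48 log units; beyond the scatter). The two compounds without a methoxy or nitro group stay out of exact reach: the limit of > 100000 nM in this assay, at which 2 of the 4 values shown sit.

What the compounds shown leave open is why methoxy has this effect. As far as these compounds go, whether an ethoxy group or an amine at this position would act the same way also stays open.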